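Notes: fluoro to trifluoromethyl, compound 3 to compound 4

A few compounds are considered here, and "the series" means these few. Any claim that something is new, unique, unknown or untested is made for them only; others in the source may bear on it.

Values in a functional assay on MGC-803 cells (Homo sapiens) for antiproliferative activity, read by MTT assay, with a stated time of 48 h; on this read-out higher numbers stand for weaker inhibition and lower numbers for stronger inhibition:
- compound 1 `COc1cc(N(Cc2ccccc2)C(=O)CSc2nc3ccccc3s2)cc(OC)c1OC`: 44300 nM
- compound 2 `COc1cc(N(Cc2ccc(Cl)cc2)C(=O)CSc2nc3ccccc3s2)cc(OC)c1OC`: > 80000 nM (a limit of the assay)
- compound 3 `COc1ccc(CN(C(=O)CSc2nc3ccccc3s2)c2cc(OC)c(OC)c(OC)c2)cc1F`: 416 nM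

Compound 3 gives the lower of the two exact numbers. Compound 4 `COc1ccc(CN(C(=O)CSc2nc3ccccc3s2)c2cc(OC)c(OC)c(OC)c2)cc1C(F)(F)F` carries trifluoromethyl in place of fluoro on an aromatic carbon, ortho to a methoxy group (trifluoromethyl in place of fluoro on an aromatic carbon). The nearest measured changes replace the whole aromatic group: a 110-fold lower number from compound 1 to compound 3 (2.03 log units; beyond the scatter), and an at least 190-fold lower number from compound 2 to compound 3 (2.28 log units; beyond the scatter). Going by the values given here, neither isolates the fluoro, so they show only that this group can matter greatly. In this assay, a moderately higher number is expected, beyond the scatter but smaller than those steps. The expected change is a 4.8-fold higher number from compound 3 to compound 4 (0.68 log units; beyond the scatter). Compound 4 is estimated at 2000 nM, with an expected range of 300 nM to 20000 nM.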

Compound 4, half-maximal inhibitory concentration: 25200 nM
Beside the measured number, compound 4's estimate is 13-fold (1.10 log units) below it; the measured number lies above the stated range.
By their numbers in this assay, from the lowest: compound 3; then compounds 4 and 1 (each within the scatter of the next). At a limit, above all of these: compound 2.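

In this assay, the large gain of the 3-fluoro-4-methoxyphenyl group depends on the single substituent at this place: trifluoromethyl in place of fluoro gives a 61-fold higher number from compound 3 to compound 4 (1.78 log units; beyond the scatter). With 4-methoxy-3-(trifluoromethyl)phenyl in place of phenyl, the step is a 1.8-fold lower number from compound 1 to compound 4 (0.25 log units; within the scatter), so the gain seen with fluoro is not retained. The step to the 4-chlorophenyl compound is an at least 3.1-fold lower number from compound 2 to compound 4 (0.50 log units; beyond the scatter), but that comparison rests on a limit of the assay for compound 2, not a number: the limit of > 80000 nM in this assay, at which 1 of the 4 values shown sits.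

Still open, going by these compounds, is whether a chloro, methyl or hydroxyl at this place behaves like fluoro or like trifluoromethyl. Also open, on these data alone, is whether fluoro retains the gain without the methoxy group.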